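The source may report more compounds than this note shows. Statements on the series, on what has been measured and on what is new or still open speak of the compounds shown alone.

Measured so far:
compound 1 `O=c1cc(/C=N\c2ccccc2O)c2c(OCc3ccccc3)cc(OCc3ccccc3)cc2o1` — 7760 nM
compound 2 `O=c1cc(/C=N\Nc2ccc([N+](=O)[O-])cc2)c2ccc(OCc3ccccc3)cc2o1` — 9510 nM
compound 3 `N/N=C\c1cc(=O)oc2cc(OCc3ccccc3)ccc12` — 9740 nM

All three numbers come from a functional assay, read by spectrophotometry, with a stated time of 3 min; on this read-out higher numbers stand for weaker inhibition and lower numbers for stronger inhibition. Among the compounds with values here, they lie within the scatter of one another: the step of a 1.0-fold higher number from compound 2 to compound 3 (0.01 log units; within the scatter) is negligible, and compound 1 with 7760 nM differs from compound 3 only within the usual spread, so no compound can be set apart from the others.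

Compound 4 `O=c1cc(/C=N\c2ccccc2O)c2ccc(OCc3ccccc3)cc2o1` has not yet been measured. It differs from compound 3 by 2-hydroxyphenyl in place of amino on a double-bonded nitrogen.

Two observations bear on this change. First, the step of a 1.0-fold higher number from compound 2 to compound 3 (0.01 log units; within the scatter) shows that removing a substituted aromatic ring from the neighbouring nitrogen left the number essentially unchanged. Second, compound 1 already carries the same 2-hydroxyphenyl group on a double-bonded nitrogen, and its value 7760 nM sits within the scatter of compound 3, although compound 1 also carries a second benzyloxy group, so this is not a clean comparison.

Taken together, no step beyond the scatter is expected in this assay. For compound 4 the estimate is 8500 nM, with a range from 4000 nM to 18000 nM; the expected step is a 1.1-fold lower number from compound 3 to compound 4 (0.06 log units; within the scatter).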

Compound 4, half-maximal inhibitory concentration: 1290 nM
The estimate for compound 4 lay 6.6-fold (0.82 log units) above the measured number, outside the stated range (below it).
By their numbers in this assay, from the lowest: compound 4; then compounds 1, 2 and 3 (each within the scatter of the next).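

In this assay, within the data shown here, the group on the double-bonded nitrogen turns out to matter, which the earlier compounds, all alike in number, gave no sign of: 2-hydroxyphenyl in place of amino brings a 7.6-fold lower number from compound 3 to compound 4 (0.88 log units; beyond the scatter) and 2-hydroxyphenyl in place of (4-nitrophenyl)amino brings a 7.4-fold lower number from compound 2 to compound 4 (0.87 log units; beyond the scatter) on an otherwise unchanged structure. A second change counts as well, since hydrogen in place of benzyloxy on an aromatic carbon brings a 6.0-fold lower number from compound 1 to compound 4 (0.78 log units; beyond the scatter) and so the earlier match in numbers did not mean that 2-hydroxyphenyl was without effect; it gives its lower number only on the core lacking that extra benzyloxy group. No measurement here explains either change.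

On these data alone, it remains open whether the whole 2-hydroxyphenyl group is needed or only part of it, which plain phenyl or 2-methoxyphenyl on the same nitrogen would help to separate. As far as these compounds go, it is also open whether a smaller group, such as methoxy, could stand in place of the remaining benzyloxy group without losing the lower number.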